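The compounds below may be only part of what the source reports. "The series", "measured", "known", "first", "only" and "open" are said of these compounds alone.

In a functional assay on U-251 cells (Homo sapiens) for inhibition, read by sulforhodamine B assay, with a stated time of 48 h (a lower number here means a stronger inhibitor of growth, a higher number a weaker inhibitor of growth), three analogues built on one shared core have been measured. Compound 1 `CC1(/C=C/c2ccccc2O)C=CC(=O)O1` gives 70900 nM. Compound 2 `CC1(/C=C/c2ccc(O)cc2)C=CC(=O)O1` has the same atoms as compound 1 joined differently; the difference between the two cores is not broken down here. In this assay compound 2 gives 107000 nM, and the two numbers of compound 1 and compound 2 lie within the usual scatter of each other. Compound 3 `COc1ccccc1/C=C/C1(C)C=CC(=O)O1` gives 41100 nM, a number lower than that of compound 2 by a gap that goes beyond the scatter.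

Compound 3 arises from compound 1 by a single change, (methyl in place of hydrogen on an oxygen on an aromatic ring), and this change produced a 1.7-fold lower number from compound 1 to compound 3 (0.24 log units; within the scatter), a step that stays within the scatter.

Compound 4 `COc1ccc(/C=C/C2(C)C=CC(=O)O2)cc1` has not yet been measured in this assay. Among the compounds with values here, it differs from compound 2 by methyl in place of hydrogen on an oxygen on an aromatic ring, which is the same change as the one that turns compound 1 into compound 3. The step from compound 2 to compound 4 is therefore expected to be a 1.7-fold lower number from compound 2 to compound 4 (0.23 log units; within the scatter), because the same change gave a 1.7-fold lower number from compound 1 to compound 3 (0.24 log units; within the scatter). This rests on a single earlier step and on the two cores being related, so the expectation is loose. Compound 4 is expected to give about 63000 nM in this assay, with a plausible range from 28000 nM to 150000 nM.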

Compound 4, concentration for total growth inhibition: 127000 nM
Compound 4: middle estimate off by 2.0-fold (0.30 log units), on the low side, within the range that was stated.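

In this assay, putting methyl in place of hydrogen on an oxygen on an aromatic ring, which reads as hydroxy to methoxy, gives a 1.2-fold higher number from compound 2 to compound 4 (0.07 log units; within the scatter), and set beside the earlier step on the other core it reads: the same change on two cores in this assay, a 1.7-fold lower number (0.24 log units; within the scatter) from compound 1 to compound 3 and a 1.2-fold higher number (0.07 log units; within the scatter) from compound 2 to compound 4, 2.0-fold (0.31 log units) apart, within the scatter of two such steps

Both steps stay within the scatter and so does the gap between them, which means that this change, carried from one core to the other, shows no effect on either core that can be told from repeat noise, and the opposite directions of the two printed steps should not be read as a reversal. This does not show that the two cores respond alike or that the change is without effect, since two small steps cannot reveal a modest real difference between the cores and offer no basis for a rule that reaches beyond these four compounds.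

The compounds shown leave open whether a longer chain than methyl on that oxygen would move the number beyond the scatter. On these data alone, it also remains open whether an amine or a carboxylic acid in place of the hydroxy would do so, on either core.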